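Adding a methyl to the acetyl end of compound 2

A few compounds are considered here, and "the series" means these few. Any claim that something is new, unique, unknown or untested is made for them only; others in the source may bear on it.

- compound 1 `CN(C(=O)CNC(=O)CN1CCCCC1)c1ccc(Cl)cc1C(=O)c1ccccc1Cl`: 7.5 mg/kg
- compound 2 `CC(=O)NCC(=O)N(C)c1ccc(Cl)cc1C(=O)c1ccccc1Cl`: 2.3 mg/kg
- compound 3 `NC(C(=O)NCC(=O)Nc1ccc(Cl)cc1C(=O)c1ccccc1)c1ccccc1`: 28 mg/kg

In a functional assay on the whole organism for antagonist activity, with Mus musculus as the target (a higher number here means that more compound is needed for the effect, a lower number that less compound is needed), compound 2 gives the lowest number of the three, 2.3 mg/kg. Next comes compound 1 at 7.5 mg/kg, and compound 3 has the highest number at 28 mg/kg.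

The next compound, still unmeasured, is compound 4 `CCC(=O)NCC(=O)N(C)c1ccc(Cl)cc1C(=O)c1ccccc1Cl`. Its difference from compound 2 is methyl in place of hydrogen on a saturated chain carbon bound to a carbonyl carbon.

Among the compounds with values here, only one measured step touches this place: a 3.3-fold lower number from compound 1 to compound 2 (0.51 log units; beyond the scatter), with hydrogen in place of piperidin-1-yl. That step is modest, and it involves a ring rather than a methyl. Compound 3 differs from compound 2 in more than one place, so it offers no direct guide. Within the data shown here, with no measured methyl step at this place, the direction of the step from piperidin-1-yl to hydrogen gives only a weak hint of a slightly higher number in this assay.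

The expected change is a 1.3-fold higher number from compound 2 to compound 4 (0.12 log units; within the scatter), which would be small. The estimated value for compound 4 is 3 mg/kg, with an expected range from 1.2 mg/kg to 7.5 mg/kg.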

Compound 4, dose for half-maximal effect: 1.4 mg/kg
Compound 4: middle estimate off by 2.1-fold (0.33 log units), on the high side, and the stated range covers the measured number.
By their numbers in this assay, from the lowest: compounds 4 and 2 (each within the scatter of the next); then compound 1; then compound 3.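

In this assay, methyl in place of hydrogen on a saturated chain carbon bound to a carbonyl carbon gives a 1.6-fold lower number from compound 2 to compound 4 (0.22 log units; within the scatter), so the acetyl and propanoyl ends cannot be told apart at this position. Methyl in place of piperidin-1-yl at the same carbon gives a 5.4-fold lower number from compound 1 to compound 4 (0.73 log units; beyond the scatter), which runs the same way as a 3.3-fold lower number from compound 1 to compound 2 (0.51 log units; beyond the scatter), so both compound 2 and compound 4 stand apart from compound 1 by more than the scatter. No available measurement bears on the origin of these steps.

Open, going by these compounds, is whether a longer chain such as butanoyl stays level with the propanoyl end or moves the number beyond the scatter. Also open, on these data alone, is whether a small amine such as dimethylamino at this carbon behaves like methyl or like piperidin-1-yl.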